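The source may report more compounds than this note shows. Statements on the series, on what has been measured and on what is new or still open speak of the compounds shown alone.

In a functional assay on MCF7 cells (Homo sapiens) for antiproliferative activity, read by MTT assay, with a stated time of 48 h (a higher number here means a weaker inhibitor, a lower number a stronger inhibitor), compound 1 `COc1ccc(-c2nn(-c3ccccc3)cc2CNc2ccc(Br)cc2)cc1` gives 7020 nM, while compound 2 `Cc1ccc(NCc2cn(-c3ccccc3)nc2-c2ccc(Cl)cc2)cc1` gives 3110 nM, the lower of the two numbers and a gap beyond the scatter. Compound 3 `Fc1ccc(NCc2cn(-c3ccccc3)nc2-c2ccc(Cl)cc2)cc1` has not yet been measured. Compared with compound 2, it carries fluoro in place of methyl on an aromatic carbon, para to a large group (fluoro in place of methyl on an aromatic carbon). Going by the values given here, no measured pair shows this change, so no shift beyond the scatter is expected, and no direction can be favoured. The expected size is a 1.1-fold higher number from compound 2 to compound 3 (0.05 log units; within the scatter). Compound 3 is estimated at 3500 nM, within an expected range of 1300 nM to 9000 nM.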

Compound 3, half-maximal inhibitory concentration: 1880 nM
For compound 3 the middle estimate is 1.9-fold (0.27 log units) above the measured one; measured number inside the range.
By their numbers in this assay, from the lowest: compounds 3 and 2 (each within the scatter of the next); then compound 1.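

Going by these compounds alone, with a 1.7-fold lower number from compound 2 to compound 3 (0.22 log units; within the scatter) in this assay, this is the first step between measured compounds that differ in one place. It shows that, on this aromatic carbon para to a large group, fluoro in place of methyl brings no shift beyond the scatter, so the two groups cannot be told apart here. Nothing measured bears on the reason for this result. Going by these compounds, whether an amine or a carboxylic acid at this position would give a shift beyond the scatter remains open. So does whether fluoro in place of methyl would read the same way on another core.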